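The source may hold more compounds than are shown below. What is called first, only, known or untested is meant among the compounds shown, and "the series" means these compounds.

Measured compounds:
compound 1 `CCOc1cc(C(C)(C)C)ccc1C1=NC(c2ccc(Cl)cc2)C(c2ccc(Cl)cc2)N1C(=O)NCCCCC(=O)Nc1ccccc1N` — in a functional assay on MCF7 cells (Homo sapiens) for antiproliferative activity, read by CCK-8 assay, with a stated time of 72 h (on this read-out lower numbers stand for stronger inhibition and higher numbers for weaker inhibition), compound 1 gives 29100 nM
compound 2 `CCOc1cc(C(C)(C)C)ccc1C1=NC(c2ccc(Cl)cc2)C(c2ccc(Cl)cc2)N1C(=O)N1CCN(CCCCCCCC(=O)NO)CC1` — compound 2 gives 4830 nM
compound 3 `CCOc1cc(C(C)(C)C)ccc1C1=NC(c2ccc(Cl)cc2)C(c2ccc(Cl)cc2)N1C(=O)NCCCCCCCC(=O)NO` — compound 3 gives 7920 nM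

Compound 2 holds the lowest of the three numbers in this assay; its gap to compound 3 lies within the scatter, its gap to compound 1 beyond it, so compound 2 and compound 3 cannot be ranked against each other. Going by the values given here, the only single-point step measured is a 3.7-fold lower number from compound 1 to compound 3 (0.57 log units; beyond the scatter), in which 3-(hydroxycarbamoyl)propyl stands in place of (2-aminophenyl)carbamoyl; it concerns the group at the chain end, not the chain itself.

Compound 4 `CCOc1cc(C(C)(C)C)ccc1C1=NC(c2ccc(Cl)cc2)C(c2ccc(Cl)cc2)N1C(=O)N1CCN(CCCCCC(=O)NO)CC1` differs from compound 2 by hydroxycarbamoyl in place of 2-(hydroxycarbamoyl)ethyl on a saturated chain carbon, five bonds along the chain from an amine nitrogen in a ring. Among the compounds with values here, no measured pair isolates a change of this kind, so the step from compound 1 to compound 3 gives no direct guide, and a change no larger than the scatter is expected, with any drift more likely toward a higher number. Compound 4 is expected to give about 6500 nM in this assay, between 2500 nM and 17000 nM. That expectation amounts to a 1.3-fold higher number from compound 2 to compound 4 (0.13 log units; within the scatter).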

Compound 4, half-maximal inhibitory concentration: 7260 nM
Beside the measured number, compound 4's estimate is 1.1-fold (0.05 log units) below it, and the stated range covers the measured number.
By their numbers in this assay, from the lowest: compounds 2, 4 and 3 (each within the scatter of the next); then compound 1.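

Going by these compounds alone, this is the first measured step that concerns the chain itself rather than the group at its end: hydroxycarbamoyl in place of 2-(hydroxycarbamoyl)ethyl on a saturated chain carbon, five bonds along the chain from an amine nitrogen in a ring, gives a 1.5-fold higher number from compound 2 to compound 4 (0.18 log units; within the scatter) in this assay. The read-out therefore does not separate these two chain lengths, and the shortening costs nothing that can be resolved at this place. No measurement at hand accounts for this result.

As far as these compounds go, what a longer chain or a carboxylic acid at the chain end would do at this place remains open. From the compounds shown here alone, it is also open whether the same insensitivity to chain length would hold with (2-aminophenyl)carbamoyl as the end group.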